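A few compounds are considered here, and "the series" means these few. Any claim that something is new, unique, unknown or untested is made for them only; others in the source may bear on it.

In a functional assay on SW-620 cells (Homo sapiens) for cytotoxicity, read by MTT assay, with stated times of 4 h and 72 h, tested at 5 uM (on this read-out lower numbers stand for stronger inhibition and higher numbers for weaker inhibition), compound 1 `Cc1ccc(CSc2nc3nc(C)cc(Nc4ccc(C(=O)/C=C/c5ccc6ccccc6c5)cc4)n3n2)cc1` gives 880 nM, compound 2 `Cc1cc(Nc2ccc(C(=O)/C=C/c3ccc4ccccc4c3)cc2)n2nc(SCc3ccc([N+](=O)[O-])cc3)nc2n1` gives 1130 nM and compound 3 `Cc1cc(Nc2ccc(C(=O)/C=C/c3ccc4ccccc4c3)cc2)n2nc(SCc3ccc(F)cc3)nc2n1` gives 320 nM. Compound 2 therefore stands at the high, weaker end of these numbers, together with compound 1. The two cannot be told apart, as a 1.3-fold higher number from compound 1 to compound 2 (0.11 log units; within the scatter) shows, while compound 3 lies clearly lower.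

Compound 4 `Cc1cc(Nc2ccc(C(=O)/C=C/c3ccc4ccccc4c3)cc2)n2nc(SCc3ccccc3[N+](=O)[O-])nc2n1` has the same atoms as compound 2, joined differently: 4-nitrobenzyl becomes 2-nitrobenzyl (2-nitrophenyl in place of 4-nitrophenyl on a saturated chain carbon bound to a sulfur). Going by the values given here, no measured step moves a group to another place in this way, so the evidence is only indirect. It comes from replacing the group outright. Fluoro in place of nitro gave a 3.5-fold lower number from compound 2 to compound 3 (0.55 log units; beyond the scatter), and fluoro in place of methyl gave a 2.8-fold lower number from compound 1 to compound 3 (0.44 log units; beyond the scatter). Even these changes of group produced only modest steps, so a mere shift of the nitro group is expected to stay within the scatter in this assay, with no firm direction. The estimated step is a 1.1-fold lower number from compound 2 to compound 4 (0.05 log units; within the scatter). For compound 4 the estimate is 1000 nM, with an expected range from 380 nM to 2600 nM.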

Compound 4, half-maximal inhibitory concentration: 960 nM
Compound 4: middle estimate off by 1.0-fold (0.02 log units), on the high side, within the range that was stated.
By their numbers in this assay, from the lowest: compound 3; then compounds 1, 4 and 2 (each within the scatter of the next).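

In this assay, going by these compounds alone, the shift from 4-nitrobenzyl to 2-nitrobenzyl gives the first direct look at where a group sits on this benzyl ring, and it produces no change that can be told from the scatter (a 1.2-fold lower number from compound 2 to compound 4 (0.07 log units; within the scatter)). The 2-nitrophenyl group also cannot be separated from 4-methylphenyl (a 1.1-fold higher number from compound 1 to compound 4 (0.04 log units; within the scatter)), whereas 4-fluorophenyl stays apart from it (a 3.0-fold higher number from compound 3 to compound 4 (0.48 log units; beyond the scatter)), so only the fluoro compound stands out among these four. No supporting measurement is available to explain this difference.

From the compounds shown here alone, whether fluoro would behave like nitro on moving to give a 2-fluorophenyl group remains open, as does how an amine or a carboxylic acid on this ring would compare. A longer chain between the sulfur and the ring is likewise an open question.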